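Pentyl to propyl on the quinoline-type core: compound 4 estimate

The source may hold more compounds than are shown below. What is called first, only, known or untested is meant among the compounds shown, and "the series" means these compounds.

Measured compounds in a functional assay on U-937 cells (Homo sapiens) for cytotoxicity, read by MTT assay, with a stated time of 24 h; a lower number here means a stronger inhibitor, a higher number a weaker inhibitor:
compound 1 `CCCCCc1cc2ccccc2nc1-c1cn(CCC(F)(F)C(F)(F)C(F)(F)C(F)(F)C(F)(F)C(F)(F)C(F)(F)C(F)(F)F)nn1`: > 100 ug/mL.
compound 2 `Cc1cc2ccccc2nc1-c1cn(-c2ccc(F)cc2)nn1`: 65.6 ug/mL.
compound 3 `CCCc1cc2ccccc2nc1-c1cn(-c2ccc(F)cc2)nn1`: 67.4 ug/mL.

For compound 1 the value is a limit of the assay, not a number: compound 1 gives > 100 ug/mL in this assay, so it stands at the limit of > 100 ug/mL in this assay, at which 1 of the 3 values shown sits, and no finer placement among the three is possible. Compound 2 gives 65.6 ug/mL and compound 3 gives 67.4 ug/mL; the change between them, a 1.0-fold higher number from compound 2 to compound 3 (0.01 log units; within the scatter), lies within the scatter.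

Compound 4 `CCCc1cc2ccccc2nc1-c1cn(CCC(F)(F)C(F)(F)C(F)(F)C(F)(F)C(F)(F)C(F)(F)C(F)(F)C(F)(F)F)nn1` differs from compound 1 by hydrogen in place of ethyl on a saturated chain carbon, three bonds along the chain from an aromatic carbon. For the measured compounds named here, the only measured step that touches this chain, a 1.0-fold higher number from compound 2 to compound 3 (0.01 log units; within the scatter), runs in the other direction (chain lengthened) and moved nothing beyond the scatter. Chain length at this position has therefore shown no effect in the two pairs at hand, though the pair 2 and 3 carries a different substituent on the triazole than compounds 1 and 4.

Compound 4 is accordingly expected near the same limit region, with an expected step that the limit leaves unreadable from compound 1 to compound 4; the estimate for compound 4 is 120 ug/mL, with a range from 50 ug/mL to 300 ug/mL, and it is expected that the assay will most likely again report only a limit.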

Compound 4, half-maximal inhibitory concentration: > 100 ug/mL
Compound 4: no number, only a limit; the forecaster's own chance of this, stated with the estimate: 70%; the middle value is on the limit's open side.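

In this assay compound 1 and compound 4 each stand only at a limit of the assay, so no step between them can be read: the limit of > 100 ug/mL in this assay, at which 2 of the 4 values shown sit.

The compounds shown leave open what number either compound would give, and so whether pentyl to propyl changes anything in this pair.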